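The compounds below may be only part of what the source reports. "The series", "measured", "known", "first", "only" and "open" are said of these compounds alone.

Measured so far in a functional assay on MKN-74 cells (Homo sapiens) for antiproliferative activity, with a stated time of 24 h; on this read-out lower numbers stand for stronger inhibition and higher numbers for weaker inhibition:
- compound 1, `NC(=O)c1c(NC(=O)c2ccccc2Cl)sc2c1CCN(Cc1cc(Cl)cc(Cl)c1)C2`: 23700 nM
- compound 2, `NC(=O)c1c(NC(=O)c2cccc([N+](=O)[O-])c2)sc2c1CCN(Cc1ccc(Cl)cc1Cl)C2`: 16500 nM

Compound 1 has the higher of the two numbers, but the gap to compound 2 lies within the usual scatter of repeated measurements, so the two cannot be told apart on these data. Both sit in a weakly active range on this assay. Among the measured compounds shown here, no step between measured compounds that differ in one place is available, so nothing about the effect of any single change is known from the series itself.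

Compound 3, `NC(=O)c1c(NC(=O)c2ccccc2Cl)sc2c1CCN(C(=S)Nc1cccnc1)C2`, is not yet measured. Relative to compound 1 the change is a group of 9 heavy atoms (6 carbon, 2 nitrogen, 1 sulfur; one six-membered aromatic ring with 1 hetero atom) in place of a group of 9 heavy atoms (7 carbon, 2 chlorine; one six-membered aromatic ring of carbon only), on an amine nitrogen in a ring. For the measured compounds named here, the group that enters is of a different kind from the one that leaves, yet there is no measured pair to show how such an exchange plays out here. The expected step of a 1.2-fold lower number from compound 1 to compound 3 (0.07 log units; within the scatter) is therefore none beyond the scatter, with the direction left open. For compound 3 the estimate is 20000 nM, with a range from 5000 nM to 80000 nM.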

Compound 3, half-maximal inhibitory concentration: 38600 nM
Beside the measured number, compound 3's estimate is 1.9-fold (0.29 log units) below it; the measured number falls inside the stated range.
By their numbers in this assay, from the lowest: compounds 2, 1 and 3 (each within the scatter of the next, the first and the last beyond it).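

On the amine nitrogen in the ring, this assay now has its first step between compounds that differ in one place: a 1.6-fold higher number from compound 1 to compound 3 (0.21 log units; within the scatter). This step lies within the scatter, so 3,5-dichlorobenzyl and the entering group, with its six-membered aromatic ring with 1 hetero atom, 1 hydrogen-bond donor and 2 hydrogen-bond acceptors, cannot be told apart here, and this position takes a group of a different kind without a step beyond the scatter. No outside measurement bears on this result.

From the compounds shown here alone, whether an unsubstituted benzyl, or a longer chain ending in an amine or a carboxylic acid, on this nitrogen would give a step beyond the scatter remains open. Also open, going by these compounds, is whether the same exchange reads alike with a different acyl group on the shared core.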